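Replacing 2,3-dimethoxyphenyl with furan-2-yl in a small series

The source may hold more compounds than are shown below. What is called first, only, known or untested is meant among the compounds shown, and "the series" means these compounds.

Measured compounds in a functional assay on MCF7 cells (Homo sapiens) for cytotoxicity, read by MTT assay, with a stated time of 72 h; a lower number here means a stronger inhibitor, a higher number a weaker inhibitor
compound 1 `O=C1C(=Cc2ccc(F)cc2)C(=O)N(c2ccc(Cl)cc2)N1c1ccc(Cl)cc1` gives 31400 nM
compound 2 `O=C1C(=Cc2cccc(Cl)c2)C(=O)N(c2ccc(Cl)cc2)N1c1ccc(Cl)cc1` gives 18300 nM
compound 3 `COc1cccc(C=C2C(=O)N(c3ccc(Cl)cc3)N(c3ccc(Cl)cc3)C2=O)c1OC` gives 11900 nM

Compound 3 cannot be told apart from its nearest neighbour, given a 1.5-fold lower number from compound 2 to compound 3 (0.19 log units; within the scatter) between them, and the only separation beyond the scatter is a 2.6-fold lower number from compound 1 to compound 3 (0.42 log units; beyond the scatter) in this series. The next compound, compound 4 `O=C1C(=Cc2ccco2)C(=O)N(c2ccc(Cl)cc2)N1c1ccc(Cl)cc1`, has not yet been measured in this assay and differs from compound 3 by furan-2-yl in place of 2,3-dimethoxyphenyl on a double-bonded chain carbon bound to a double-bonded ring carbon on a double-bonded chain carbon bound to a double-bonded ring carbon. Changes at this place have moved the number little so far, with a 1.7-fold lower number from compound 1 to compound 2 (0.23 log units; within the scatter) as the third measured step. For the measured compounds named here, none of the measured compounds carries a five-membered aromatic ring, so no direct precedent exists. With compound 1 at 31400 nM as the far end of the range, a small rise from compound 3 is expected, close to the edge of the scatter. For compound 4 the expected change is a 1.7-fold higher number from compound 3 to compound 4 (0.23 log units; within the scatter) in size and no larger than a modest step. The estimated value for compound 4 is 20000 nM with an expected range from 8000 nM to 45000 nM as its bounds.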

Compound 4, half-maximal inhibitory concentration: 20300 nM
Compound 4: middle estimate off by 1.0-fold (0.01 log units), on the low side; the range from low to high includes it.
By their numbers in this assay, from the lowest: compounds 3, 2, 4 and 1 (each within the scatter of the next, the first and the last beyond it).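

In this assay the first five-membered aromatic ring at this place, on a double-bonded chain carbon bound to a double-bonded ring carbon, cannot be told apart from any of the three six-membered aromatic rings before it (a 1.7-fold higher number from compound 3 to compound 4 (0.23 log units; within the scatter); a 1.1-fold higher number from compound 2 to compound 4 (0.05 log units; within the scatter); a 1.5-fold lower number from compound 1 to compound 4 (0.19 log units; within the scatter)). Furan-2-yl has fewer heavy atoms and fewer hydrogen-bond acceptors than 2,3-dimethoxyphenyl, yet this exchange gives no separation beyond the scatter, so ring size and these counts show no separable link to the number here. No measurement bearing on the reason for this result is available.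

On these data alone, whether a thiophen-2-yl ring, a pyridine ring or a carboxylic acid at this place would give a larger separation remains open. As far as these compounds go, the part played by the 4-chlorophenyl groups, which all four compounds share, is also open.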